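The compounds below may be only part of what the source reports. "The series", "measured", "known", "first", "only" and "open" are said of these compounds alone.

Going by the values given here, compound 3 `O=C(Nc1nc2ccc(F)cc2s1)c1cn(-c2ccccc2)nc1-c1ccc(F)cc1` is one of three compounds measured in an ADME assay on HEK-293T cells (Homo sapiens) for cytotoxicity, read by MTT assay, with a stated time of 72 h; on this read-out lower numbers stand for stronger inhibition and higher numbers for weaker inhibition. In this assay compound 3 gives 16700 nM, compound 1 `O=C(Nc1nc2ccc(Cl)cc2s1)c1cn(-c2ccccc2)nc1-c1ccccc1` gives 21300 nM and compound 2 `O=C(Nc1nc2ccccc2s1)c1cn(-c2ccccc2)nc1-c1ccc(F)cc1` gives 33400 nM, all three within the scatter of one another. Among the compounds with values here, the only single-point step recorded, a 2.0-fold lower number from compound 2 to compound 3 (0.30 log units; within the scatter), stays within the scatter. Compound 4 `O=C(Nc1nc2ccc(Cl)cc2s1)c1cn(-c2ccccc2)nc1-c1ccc(F)cc1` differs from compound 3 by chloro in place of fluoro on an aromatic carbon. Within the data shown here, no measured step covers that exchange directly; compound 1 and compound 3 carry chloro and fluoro at the same place on the fused ring, and their two values lie within the scatter. Compound 4 is therefore expected to show a 1.1-fold higher number from compound 3 to compound 4 (0.06 log units; within the scatter), no change beyond the scatter, with an estimated value of 19000 nM and a range from 9000 nM to 40000 nM.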

Compound 4, half-maximal inhibitory concentration: 45700 nM
Estimate against measurement, compound 4: 2.4-fold (0.38 log units) below; measured number above the stated range.
By their numbers in this assay, from the lowest: compounds 3, 1, 2 and 4 (each within the scatter of the next, the first and the last beyond it).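

In this assay, chloro and fluoro at this place are not interchangeable on this core: the exchange gives a 2.7-fold higher number from compound 3 to compound 4 (0.44 log units; beyond the scatter), a modest step, while chloro in place of hydrogen gives a 1.4-fold higher number from compound 2 to compound 4 (0.14 log units; within the scatter). Fluoro in place of hydrogen on the core of compound 1 gives a 2.1-fold higher number from compound 1 to compound 4 (0.33 log units; beyond the scatter), so this change does not read the same on the two cores: the same change on two cores in this assay, a 2.0-fold lower number (0.30 log units; within the scatter) from compound 2 to compound 3 and a 2.1-fold higher number (0.33 log units; beyond the scatter) from compound 1 to compound 4, 4.3-fold (0.63 log units) apart, beyond the scatter of two such steps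

The compounds shown leave open whether the step from fluoro to chloro holds on another core. They also leave open how a methoxy group or an amine at this place would compare with chloro and fluoro.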